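Replacing the iodophenyl of compound 1 with a dimethylphenyl

This account rests on a few compounds, and the source may have more. Where it says the series, first, only, none or still open, it means among the compounds named here.

Compound 1 `O=C1NCCN1c1ccc(S(=O)(=O)Nc2ccc(I)cc2)cc1` gives 260 nM in a functional assay on M21 cells (Homo sapiens) for antiproliferative activity, read by sulforhodamine B assay, with a stated time of 48 h (a higher number here means a weaker inhibitor, a lower number a stronger inhibitor), the lowest of the three numbers at hand. Compound 2 `O=C1NCCN1c1ccc(S(=O)(=O)Nc2ccc(OC(F)F)cc2)cc1` gives 410 nM, and compound 3 `CCCCOc1ccc(NS(=O)(=O)c2ccc(N3CCNC3=O)cc2)cc1` gives 580 nM. The steps from it are small: a 1.6-fold higher number from compound 1 to compound 2 (0.20 log units; within the scatter) and a 2.2-fold higher number from compound 1 to compound 3 (0.35 log units; beyond the scatter). Compound 4 `Cc1ccc(C)c(NS(=O)(=O)c2ccc(N3CCNC3=O)cc2)c1` differs from compound 1 by 2,5-dimethylphenyl in place of 4-iodophenyl on a sulfonamide nitrogen. Both measured changes at this end of the molecule moved the number upward only slightly, so a similar, modest rise is expected here. The expected step is a 1.9-fold higher number from compound 1 to compound 4 (0.28 log units; within the scatter). Compound 4 is therefore estimated at 500 nM, within a range of 200 nM to 1300 nM.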

Compound 4, half-maximal inhibitory concentration: 27 nM
Beside the measured number, compound 4's estimate is 19-fold (1.27 log units) above it; measured number below the stated range.
By their numbers in this assay, from the lowest: compound 4; then compounds 1, 2 and 3 (each within the scatter of the next, the first and the last beyond it).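

In this assay, among these compounds, the group on the sulfonamide nitrogen can move the number much further than the earlier compounds suggested: 2,5-dimethylphenyl in place of 4-iodophenyl gives a 9.6-fold lower number from compound 1 to compound 4 (0.98 log units; beyond the scatter). Among the compounds shown here, compound 4 is also the only compound here with two groups on this ring, so the number of groups and their identity change together. Nothing at hand bears on why the number falls.

As far as these compounds go, it remains open whether a phenyl with a single methyl would keep this low number. From the compounds shown here alone, it is equally open how an amine or a carboxylic acid on this ring would read.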